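Adding a Methoxy Group to Compound 2

The source may hold more compounds than are shown below. What is called first, only, known or untested is meant among the compounds shown, and "the series" means these compounds.

compound 1 `COc1cc2occ(-c3csc4ccccc34)c(=O)c2c(OC)c1OC`: 640 nM
compound 2 `COc1cc2occ(-c3csc4ccccc34)c(=O)c2cc1OC`: > 10000 nM

In a functional assay on A549 cells (Homo sapiens) for antiproliferative activity, read by sulforhodamine B assay, with a stated time of 72 h (a lower number here means a stronger inhibitor, a higher number a weaker inhibitor), compound 2 stands at > 10000 nM, and this is a limit of the assay, not a number. Compound 3 `COc1cc2c(=O)c(-c3csc4ccccc34)coc2c(OC)c1OC` is made from compound 2 by one change: methoxy in place of hydrogen on an aromatic carbon. The new methoxy sits on an aromatic carbon, ortho to a fused ring and ortho to a methoxy group. Within the data shown here, the one measured step that bears on this is an at least 15-fold higher number from compound 1 to compound 2 (1.19 log units; beyond the scatter), a large step beyond the scatter, with hydrogen in place of methoxy on an aromatic carbon. Read backwards, that step suggests that an added methoxy can lower the number. It involved a different aromatic carbon, however, so it is only a rough guide. The expected change is an at least 3.3-fold lower number from compound 2 to compound 3 (0.52 log units; beyond the scatter), toward stronger inhibition in this assay, though another limit remains possible. Compound 3 is estimated at 3000 nM, with an expected range of 500 nM to 10000 nM.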

Compound 3, half-maximal inhibitory concentration: > 10000 nM
Compound 3: a limit, no number; the forecaster's own chance of this, stated with the estimate: 35%; middle value at least 3.3-fold (0.52 log units) away from the limit.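

Among these compounds, no step from compound 2 to compound 3 can be read in this assay, since both compounds end at the same limit of the assay, not at a number: the limit of > 10000 nM in this assay, at which 2 of the 3 values shown sit.

The compounds shown leave open whether the methoxy that compound 3 gains changes antiproliferative activity at all.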